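The compounds below may be only part of what the source reports. "The series", "measured", "known", "first", "only" and "open" are said of these compounds alone.

Of the compounds shown here, three built on a shared core have been measured in a functional assay (cardiac atrium) for agonist activity, with Cavia porcellus as the target; a higher number here means that more compound is needed for the effect, a lower number that less compound is needed. Compound 1 `CO/C(O)=C1\C(C)=NC(C)=C([N+](=O)[O-])C1c1ccncc1` gives 48500 nM. Compound 2 `CC1=NC(C)=C([N+](=O)[O-])C(c2cccnc2)/C1=C(\O)OC1CCCC1` gives 3280 nM. Compound 3 `CC1=NC(C)=C([N+](=O)[O-])C(c2cccnc2)/C1=C(\O)OCC(C)C` gives 1740 nM, the lowest of the three numbers, though its gap to compound 2 is small: the step of a 1.9-fold lower number from compound 2 to compound 3 (0.28 log units; within the scatter) lies within the scatter, so those two cannot be ranked. Compound 1 differs from compound 3 in more than one place, so its far higher value cannot be traced to a single change.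

Compound 4 `CO/C(O)=C1\C(C)=NC(C)=C([N+](=O)[O-])C1c1cccnc1` is compound 3 with one change, (hydrogen in place of isopropyl on a saturated chain carbon bound to an oxygen on an unsaturated carbon); cut one bond further out, the same change reads isobutyl to methyl. Among the measured compounds shown here, only one measured step touches this group, the step of a 1.9-fold lower number from compound 2 to compound 3 (0.28 log units; within the scatter), and it stayed within the scatter. For the measured compounds named here, no measured step covers a shrink down to methyl. A smaller group at this place is expected to raise the number somewhat, so compound 4 is expected to give 6000 nM, between 2000 nM and 20000 nM, an expected step of a 3.4-fold higher number from compound 3 to compound 4 (0.54 log units; beyond the scatter).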

Compound 4, half-maximal effective concentration: 70000 nM
The estimate for compound 4 lay 12-fold (1.07 log units) below the measured number; measured number outside the range, above it.
By their numbers in this assay, from the lowest: compounds 3 and 2 (each within the scatter of the next); then compounds 1 and 4 (each within the scatter of the next).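

The size of the group on this oxygen matters more than the swap between the two larger groups suggested: isobutyl and cyclopentyl could not be told apart, yet cutting isobutyl down to methyl gives a large change (a 40-fold higher number from compound 3 to compound 4 (1.60 log units; beyond the scatter)), and replacing cyclopentyl with methyl gives one of similar size (a 21-fold higher number from compound 2 to compound 4 (1.33 log units; beyond the scatter)). With methyl on the oxygen, pyridin-3-yl in place of pyridin-4-yl on the saturated ring carbon makes no change that stands out from the scatter (a 1.4-fold higher number from compound 1 to compound 4 (0.16 log units; within the scatter)). Nothing measured here explains why the methyl compound needs so much more compound for the effect.

An ethyl or a propyl on this oxygen would show whether the number climbs gradually or suddenly as the chain shortens. Also open, on these data alone, is whether the pyridine swap would stay this small with isobutyl on the oxygen.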